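The source may report more compounds than this note shows. Statements on the series, on what has been measured and on what is new or still open speak of the compounds shown alone.

Compound 1 `CC(C(=O)NCc1ccc(C(F)(F)F)nc1-c1ccc(Cl)cc1)c1ccc(NS(C)(=O)=O)c(F)c1` gives the lowest number of the three measured compounds in an assay on CHO cells for antagonist activity at transient receptor potential cation channel subfamily V member 1 (Homo sapiens), read by FLIPR (a lower number here means a stronger inhibitor, a higher number a weaker inhibitor), at 0.7 nM. Compound 3 `CC(C(=O)NCc1ccc(C(F)(F)F)nc1-c1ccc(Cl)c(Cl)c1)c1ccc(NS(C)(=O)=O)c(F)c1` stands nearest with 0.9 nM, and the step of a 1.3-fold higher number from compound 1 to compound 3 (0.11 log units; within the scatter) lies within the scatter. Compound 2 `CC(C(=O)NCc1ccc(C(F)(F)F)nc1-c1ccc(N(C)C)cc1)c1ccc(NS(C)(=O)=O)c(F)c1` is furthest with 3.2 nM, and the step of a 4.6-fold higher number from compound 1 to compound 2 (0.66 log units; beyond the scatter) goes beyond it. Compound 4 `COc1ccc(-c2nc(C(F)(F)F)ccc2CNC(=O)C(C)c2ccc(NS(C)(=O)=O)c(F)c2)cc1OC` differs from compound 1 in one place: 3,4-dimethoxyphenyl in place of 4-chlorophenyl on an aromatic carbon. Both earlier steps bear on this change at the same aromatic carbon: adding a chloro cost little, as a 1.3-fold higher number from compound 1 to compound 3 (0.11 log units; within the scatter) shows, while replacing chloro by dimethylamino cost a modest amount, as a 4.6-fold higher number from compound 1 to compound 2 (0.66 log units; beyond the scatter) shows. Since 3,4-dimethoxyphenyl, like the dimethylamino case, removes the chlorine and brings in hydrogen-bond acceptors, a modestly higher number is expected, a 3.6-fold higher number from compound 1 to compound 4 (0.55 log units; beyond the scatter). Compound 4 is therefore estimated at 2.5 nM, within a range from 0.8 nM to 8 nM.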

Compound 4, inhibition constant: 25.6 nM
Compound 4: middle estimate off by 10-fold (1.01 log units), on the low side, outside the stated range (above it).
By their numbers in this assay, from the lowest: compounds 1 and 3 (each within the scatter of the next); then compound 2; then compound 4.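

Putting 3,4-dimethoxyphenyl at this aromatic carbon brings a 37-fold higher number from compound 1 to compound 4 (1.56 log units; beyond the scatter) and a 28-fold higher number from compound 3 to compound 4 (1.45 log units; beyond the scatter) and so weakens inhibition far more than the dimethylamino change did. Compound 2 also lacks chlorine, yet an 8.0-fold higher number from compound 2 to compound 4 (0.90 log units; beyond the scatter) still remains, so the loss of chlorine alone does not set the size of this step. Nothing measured here gives a reason for the drop.

Going by these compounds, it remains open whether a single methoxy group, as in 4-methoxyphenyl or 3-methoxyphenyl, would cost as much as the pair. It is also unknown how a 3,4-dimethylphenyl ring would compare.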